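The source may hold more compounds than are shown below. What is called first, only, known or untested is meant among the compounds shown, and "the series" means these compounds.

Compound 1 `COc1ccc(OC)c(C(=O)/C=C/c2cccs2)c1`: 3800 nM
Compound 2 `COc1ccc(OC)c(C(=O)/C=C/c2ccsc2)c1`: 3700 nM

In a functional assay on MCF7 cells (Homo sapiens) for cytotoxicity, read by MTT assay (on this read-out lower numbers stand for stronger inhibition and higher numbers for weaker inhibition), compound 2 gives 3700 nM, level with compound 1 within the scatter. Compound 3 `COc1ccc(OC)c(C(=O)/C=C/c2ccc(C)o2)c1` changes the same place: 5-methylfuran-2-yl in place of thiophen-3-yl on a double-bonded chain carbon bound to a double-bonded chain carbon. For the measured compounds named here, only one measured step bears on this place, a 1.0-fold lower number from compound 1 to compound 2 (0.01 log units; within the scatter). Going by the values given here, that step only swaps one thiophene attachment for the other, and no measured compound carries a 5-methylfuran-2-yl group, so the guide is thin. No step beyond the scatter is therefore expected, though with wide uncertainty. The estimated change is a 1.1-fold lower number from compound 2 to compound 3 (0.02 log units; within the scatter). For compound 3 the estimated value is 3500 nM, with an expected range of 1300 nM to 9500 nM.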

Compound 3, half-maximal inhibitory concentration: 10300 nM
Estimate against measurement, compound 3: 2.9-fold (0.47 log units) below; measured number outside the range, above it.
By their numbers in this assay, from the lowest: compounds 2 and 1 (each within the scatter of the next); then compound 3.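

This position is not indifferent to its ring: the two thiophene compounds sit level in this assay, yet 5-methylfuran-2-yl gives a 2.8-fold higher number from compound 2 to compound 3 (0.44 log units; beyond the scatter) and a 2.7-fold higher number from compound 1 to compound 3 (0.43 log units; beyond the scatter), which means weaker inhibition. Two things change together here, oxygen replacing sulfur in the ring and a methyl group being added, so the size of the step cannot be assigned to either one. Nothing available explains the loss.

Still open, as far as these compounds go, is what a furan-2-yl group without the methyl would give, which would separate those two changes. Also open, from the compounds shown here alone, is how a phenyl or pyridin-3-yl ring would fare at this place.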